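The source may hold more compounds than are shown below. What is called first, only, known or untested is meant among the compounds shown, and "the series" means these compounds.

In a functional assay on Huh-7 cells (Homo sapiens) for cytotoxicity, read by MTT assay, with a stated time of 72 h (on this read-out higher numbers stand for lower toxicity in this test and lower numbers for higher toxicity in this test), compound 2 `CS(=O)(=O)N1CCC2(CC1)OOC1(CCCCCC1)OO2` gives > 100 ug/mL, which is a limit of the assay and not a number. Compound 1 `CS(=O)(=O)N1CCC2(CC1)OOC1(CCN(S(C)(=O)=O)CC1)OO2` gives > 100 ug/mL, also a limit. Compound 3 `CCCCS(=O)(=O)N1CCC2(CC1)OOC1(CCCCC1)OO2`, which carries a butylsulfonyl group, gives > 100 ug/mL, again a limit. Taken together, the picture so far is the limit of > 100 ug/mL in this assay, at which 3 of the 3 values shown sit, so compound 2 stands with the other two and no exact figure is available for it.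

Compound 4 `CCCCS(=O)(=O)N1CCC2(CC1)OOC1(CCCCCC1)OO2` comes from compound 2 by one change: propyl in place of hydrogen on a saturated chain carbon bound to a sulfonyl sulfur. This turns methylsulfonyl into butylsulfonyl. Going by the values given here, no measured step is available as a guide, so the expectation rests on the limits alone. In this assay, no step beyond the usual scatter is expected in either direction, since compound 3 with its butylsulfonyl group reads > 100 ug/mL. The expected change is a number no higher from compound 2 to compound 4 (the limit leaves the size open). The estimate for compound 4 is 100 ug/mL, with an expected range from 50 ug/mL to 200 ug/mL.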

Compound 4, half-maximal cytotoxic concentration: > 100 ug/mL
Compound 4 gave a limit, no number (the forecaster's own chance of this, stated with the estimate: 80%); the middle value sits exactly at the limit.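

Compound 2 and compound 4 both give a limit and not a number, so no step between them can be read in this assay: the limit of > 100 ug/mL in this assay, at which 4 of the 4 values shown sit.

The compounds shown leave open how far past that limit each one lies, and whether they differ from one another at all.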